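This account rests on a few compounds, and the source may have more. Where it says the series, first, only, none or still open, it means among the compounds named here.

Working notes on a small series of diketopiperazine-type ligands tested in an assay on isolated protein for displacement of a labelled ligand from Oxytocin receptor (Homo sapiens); a lower number here means a stronger inhibitor, a higher number a weaker inhibitor.

Compound 1 `CCC(CC)[C@@H]1C(=O)N[C@H](C2Cc3ccccc3C2)C(=O)N1[C@@H](C(=O)N1CCOCC1)c1ccc(C)nc1` gives 0.0251 nM in this assay. Compound 2 `CCC(CC)[C@@H]1C(=O)N[C@H](C2Cc3ccccc3C2)C(=O)N1[C@@H](C(=O)N(C)C)c1ccc(C)nc1` differs from it only in the change dimethylamino in place of morpholin-4-yl on a carbonyl carbon and gives 0.0501 nM in this assay. The resulting step, a 2.0-fold higher number from compound 1 to compound 2 (0.30 log units; within the scatter), is small and does not exceed the usual scatter of the method.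

Compound 3 `COc1ccc([C@H](C(=O)N2CCOCC2)N2C(=O)[C@@H](C3Cc4ccccc4C3)NC(=O)[C@H]2CC(C)C)cn1` carries a different core; how that core differs from the core of compound 1 is not broken down here. In this assay compound 3 gives 0.251 nM, a higher number than either compound 1 or compound 2, and in both cases the gap is beyond the scatter.

Compound 4 `COc1ccc([C@H](C(=O)N(C)C)N2C(=O)[C@@H](C3Cc4ccccc4C3)NC(=O)[C@H]2CC(C)C)cn1` is the analogue of compound 3 with the change (dimethylamino in place of morpholin-4-yl on a carbonyl carbon). The place of the change is the same, word for word, as for compound 1 to compound 2, so this is the same change applied to a second core, its second occurrence in the set.

Going by the values given here, because the only measured instance of this change, a 2.0-fold higher number from compound 1 to compound 2 (0.30 log units; within the scatter), stayed within the scatter, compound 4 is expected to sit close to compound 3 in this assay. The step of a 2.0-fold higher number from compound 3 to compound 4 (0.30 log units; within the scatter) is estimated to be of similar size and direction. Compound 4 is therefore expected to give about 0.5 nM in this assay, with a plausible range from 0.2 nM to 1.3 nM; whether the second core carries the change equally well remains to be seen.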

Compound 4, inhibition constant in the Oxytocin receptor assay: 0.398 nM
Estimate against measurement, compound 4: 1.3-fold (0.10 log units) above, and the stated range covers the measured number.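

In the Oxytocin receptor assay compound 4 gives 0.398 nM; the replacement of morpholin-4-yl by dimethylamino on a carbonyl carbon gives a 1.6-fold higher number from compound 3 to compound 4 (0.20 log units; within the scatter), and the step on the second core agrees with the one on the first: the same change on two cores in the Oxytocin receptor assay, a 2.0-fold higher number (0.30 log units; within the scatter) from compound 1 to compound 2 and a 1.6-fold higher number (0.20 log units; within the scatter) from compound 3 to compound 4, 1.3-fold (0.10 log units) apart, within the scatter of two such steps. Going by these compounds alone, the change therefore carries over from the core of compound 1 to the core of compound 3 without a step that can be told from the scatter, but this rests on only two matched pairs and shows no general rule for other cores; since both steps stay within the scatter, neither a real direction nor a real size can be assigned to them. In a physicochemical assay for solubility, read by HPLC (a higher number here means a more soluble compound, a lower number a less soluble compound), compound 3 gives 249 ug/mL and compound 4 gives 216 ug/mL. Within the data shown here, in the physicochemical assay the one pair available gives a 1.2-fold lower number from compound 3 to compound 4 (0.06 log units; within the scatter), also within the scatter, and this single pair says nothing about how that read-out responds to the change on the core of compound 1.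

The compounds shown leave open how other groups on the same carbonyl carbon would behave, such as piperidin-1-yl, piperazin-1-yl or a plain primary amide, since only morpholin-4-yl and dimethylamino appear there. Also open, as far as these compounds go, is whether replacing the whole amide with a carboxylic acid would keep the numbers of the Oxytocin receptor assay in the same range.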